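The compounds below may be only part of what the source reports. "The series", "measured", "known", "first", "only" and "open" are said of these compounds alone.

Measured so far in a functional assay on MIA PaCa-2 cells (Homo sapiens) for antiproliferative activity, read by MTT assay, with a stated time of 3 days; on this read-out lower numbers stand for stronger inhibition and higher numbers for weaker inhibition:
- compound 1 `Cc1ccc(C#Cc2cn(C/C=C\CN3C(=O)c4ccccc4C3=O)c(=O)[nH]c2=O)cc1` gives > 100000 nM as a limit
- compound 2 `CCCCCc1ccc(C#Cc2cn(C/C=C\CN3C(=O)c4ccccc4C3=O)c(=O)[nH]c2=O)cc1` gives > 100000 nM as a limit

Compound 1 therefore has no exact number, only a limit, and compound 2 sits with it (the limit of > 100000 nM in this assay, at which 2 of the 2 values shown sit). Compound 3 `CCCCC#Cc1cn(C/C=C\CN2C(=O)c3ccccc3C2=O)c(=O)[nH]c1=O` has not yet been measured. It differs from compound 1 as follows: butyl in place of 4-methylphenyl on a triple-bonded carbon. For the measured compounds named here, one measured step bears on this, a step that the two limits leave unreadable from compound 1 to compound 2 (butyl in place of hydrogen). That step has no readable size, so it indicates neither a direction nor a magnitude. No step beyond the scatter is expected, and compound 3 will most likely report the same limit. The expected step is a number no higher from compound 1 to compound 3 (the limit leaves the size open) in this assay on this reasoning. Compound 3 is estimated at 100000 nM within an expected range of 30000 nM to 300000 nM in this assay.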

Compound 3, half-maximal inhibitory concentration: > 100000 nM
Compound 3 ended at the assay's limit (the forecaster's own chance of this, stated with the estimate: 80%); the middle value sits exactly at the limit.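

In this assay, for the compounds shown here, compound 1, compound 2 and compound 3 all stop at the same limit, so no step between them can be read: the limit of > 100000 nM in this assay, at which 3 of the 3 values shown sit. The compounds shown leave open how strongly each one inhibits, and whether butyl and 4-methylphenyl on the triple-bonded carbon differ at all.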